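This account rests on a few compounds, and the source may have more. Where it says the series, first, only, none or still open, it means among the compounds named here.

Compound 1 `CCCC(=O)OCSc1ccccc1C(=O)NCCC(N)=O`: > 100 uM
Compound 2 `CCCC(=O)OCSc1ccccc1C(=O)NC1(C(N)=O)CCCC1`: > 100 uM
Compound 3 `CCCC(=O)OCSc1ccccc1C(=O)NCCCC(N)=O`: 56.6 uM

All three compounds were tested in an ADME assay on CEM-SS cells (Homo sapiens) for cytotoxicity, read by XTT assay, with a stated time of 6 days; on this read-out lower numbers stand for higher toxicity in this test and higher numbers for lower toxicity in this test. Among the compounds with values here, compound 3 gives 56.6 uM, the only actual number in the set. Compound 1 reads > 100 uM, which is a limit of the assay and not a number. Compound 2 reads > 100 uM, also a limit.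

Compound 4 `CCCC(=O)OCSc1ccccc1C(=O)NCCCCCC(N)=O` differs from compound 3 by 2-carbamoylethyl in place of carbamoyl on a saturated chain carbon, three bonds along the chain from an amide-type nitrogen. Cut one bond further out, this is 3-carbamoylpropyl giving way to 5-carbamoylpentyl. The closest guide is an at least 1.7-fold lower number from compound 1 to compound 3 (0.24 log units; that floor lies within the scatter), where carbamoylmethyl replaced carbamoyl on the same chain. A less direct guide is an at least 1.7-fold lower number from compound 2 to compound 3 (0.24 log units; that floor lies within the scatter), while a step that the two limits leave unreadable from compound 1 to compound 2 gives no usable size. These steps point weakly towards a lower number, so only a small change is expected, and a return to the limit remains possible. The step is estimated as a 1.4-fold lower number from compound 3 to compound 4 (0.15 log units; within the scatter). For compound 4 the expected value is 40 uM, with an estimated range of 15 uM to 100 uM.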

Compound 4, half-maximal toxic concentration: 16.3 uM
Compound 4: the middle estimate sits 2.5-fold (0.39 log units) above what was measured; the measured number falls inside the stated range.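

In this assay, extending the chain to 5-carbamoylpentyl gives a change that can be sized between two real numbers and that clears the usual scatter: a 3.5-fold lower number from compound 3 to compound 4 (0.54 log units; beyond the scatter). Earlier, the chain changes gave only floors within the scatter, whereas this longer chain gives an at least 6.1-fold lower number from compound 1 to compound 4 (0.78 log units; beyond the scatter), and, against the ring-bearing 1-carbamoylcyclopentyl group, an at least 6.1-fold lower number from compound 2 to compound 4 (0.78 log units; beyond the scatter). These last two steps start from limits of the assay, so they give only floors and not full sizes: the limit of > 100 uM in this assay, at which 2 of the 4 values shown sit.

A chain longer than 5-carbamoylpentyl could continue this fall in the number or level off, and the compounds shown cannot tell which. They also leave open what a carboxylic acid or an amine would do at the end of the chain in place of the carbamoyl group.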